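A few compounds are considered here, and "the series" means these few. Any claim that something is new, unique, unknown or untested is made for them only; others in the source may bear on it.

Series notes. Three compounds share one core and differ only at a single group on an aromatic carbon. In an assay on isolated protein for inhibition of ubiquitin carboxyl-terminal hydrolase 7 (Homo sapiens), with stated times of 30 min and 2 h (on this read-out lower numbers stand for stronger inhibition and higher numbers for weaker inhibition), compound 1 `Cn1nc2c(=O)n(CC3(O)CCN(Cc4ccc(-c5ccco5)cc4Cl)CC3)cnc2c1-c1ccc(C(N)=O)cc1` gives 80.8 nM, compound 2 `Cn1nc2c(=O)n(CC3(O)CCN(Cc4ccc(-c5ccco5)cc4Cl)CC3)cnc2c1-c1ccc(CNC2CC2)cc1` gives 54.1 nM, and compound 3 `Cn1nc2c(=O)n(CC3(O)CCN(Cc4ccc(-c5ccco5)cc4Cl)CC3)cnc2c1-c1ccc(CNC=O)cc1` gives 20.9 nM. The steps read a 1.5-fold lower number from compound 1 to compound 2 (0.17 log units; within the scatter), a 3.9-fold lower number from compound 1 to compound 3 (0.59 log units; beyond the scatter) and a 2.6-fold lower number from compound 2 to compound 3 (0.41 log units; beyond the scatter); compound 3 therefore carries the lowest of the three numbers, and both steps toward it lie beyond the scatter.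

Compound 4 `Cn1nc2c(=O)n(CC3(O)CCN(Cc4ccc(-c5ccco5)cc4Cl)CC3)cnc2c1-c1ccc(CN)cc1` is not yet measured. It differs from compound 3 by hydrogen in place of formyl on an amine nitrogen. Within the data shown here, the one measured step at that amine nitrogen is a 2.6-fold lower number from compound 2 to compound 3 (0.41 log units; beyond the scatter), a modest shift on exchanging one group for another there; no measured compound carries hydrogen on that nitrogen, so the direction of the present step is uncertain. The step is expected to be small, with a somewhat higher number taken as the more likely outcome, and is estimated as a 1.7-fold higher number from compound 3 to compound 4 (0.22 log units; within the scatter). Compound 4 is expected to give 35 nM in this assay, within a range from 12 nM to 100 nM.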

Compound 4, half-maximal inhibitory concentration: 18.1 nM
The estimate for compound 4 lay 1.9-fold (0.29 log units) above the measured number, within the range that was stated.
By their numbers in this assay, from the lowest: compounds 4 and 3 (each within the scatter of the next); then compounds 2 and 1 (each within the scatter of the next).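

Hydrogen in place of formyl on the amine nitrogen gives a 1.2-fold lower number from compound 3 to compound 4 (0.06 log units; within the scatter), so the formyl group can go without a change that this read-out can resolve. Against cyclopropyl on the same nitrogen, hydrogen gives a 3.0-fold lower number from compound 2 to compound 4 (0.48 log units; beyond the scatter), and aminomethyl in place of carbamoyl on the aromatic carbon gives a 4.5-fold lower number from compound 1 to compound 4 (0.65 log units; beyond the scatter), so compound 3 and compound 4 both stand apart from compound 2 and compound 1 by more than the scatter. No measured evidence bears on the reason for these results.

Open, on these data alone, is whether a methyl or acetyl group on that nitrogen would stay level with hydrogen and formyl or move toward cyclopropyl. Also open, as far as these compounds go, is how a longer chain, such as aminoethyl, or a hydroxymethyl group would compare with aminomethyl on the aromatic carbon.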